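The source may hold more compounds than are shown below. What is called first, only, known or untested is meant among the compounds shown, and "the series" means these compounds.

Measured compounds:
compound 1 `N#Cc1ccccc1C1N[C@H](C(=O)O)CS1` — > 1000000 nM
compound 2 `COc1ccc(C2N[C@H](C(=O)O)CS2)cc1` — "nd(insoluble)" (no result reported)

Two compounds share the core of compound 1 and differ only in the group on the aromatic ring. In a physicochemical assay, with a stated time of 50 min (a lower number here means a stronger inhibitor, a higher number a weaker inhibitor), compound 1 reaches no number at all but only a limit, > 1000000 nM. For compound 2 the same assay gives "nd(insoluble)" (no result reported), so no result is available. Among the compounds with values here, compound 1 therefore stands at the limit of > 1000000 nM in this assay, at which 1 of the 2 values shown sits, and nothing measured lies beside it for comparison: no step between measured compounds can be drawn.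

Compound 3 `O=C(O)[C@@H]1CSC(c2ccccc2Br)N1` is not yet measured in this assay. It differs from compound 1 by bromo in place of cyano on an aromatic carbon. Since compound 1 sits at the limit of this assay, the step from compound 1 to compound 3 cannot be read in either direction from the data; the expectation is a change of no more than the usual scatter, that is, an estimated at least 1.2-fold lower number from compound 1 to compound 3 (0.09 log units; that floor lies within the scatter). Compound 3 is expected to give about 800000 nM, within a range of 100000 nM to 5000000 nM, and most likely again only a limit.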

Compound 3, half-maximal inhibitory concentration: 37700 nM
Estimate against measurement, compound 3: 21-fold (1.33 log units) above; the whole stated range lies above it.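

Bromo in place of cyano on an aromatic carbon, ortho to a group of 8 heavy atoms, gives in this assay an at least 26-fold lower number from compound 1 to compound 3 (1.42 log units; beyond the scatter). The earlier compounds shown here offered only a limit and an entry without a result, and they could not show that this position responds at all; compound 3 now shows that a change at this one place moves the read-out, and it gives the series its first single number, with the core of compound 1 left unchanged. The step remains a bound and not an exact size because compound 1 stands only at a limit: the limit of > 1000000 nM in this assay, at which 1 of the 3 values shown sits.

Compound 2 has no result, no step to it can be read, and the compounds shown therefore say nothing about how the methoxy group compares with bromo or cyano. They also leave open whether another halogen such as chloro, or a different group such as an amine or a methyl, on the same aromatic carbon would read like bromo or like cyano, and how bromo would read on another carbon of the aromatic ring.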